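The source may hold more compounds than are shown below. What is called first, only, known or untested is meant among the compounds shown, and "the series" means these compounds.

Measured so far:
Compound 1 `COc1ccc(/C=C/C(=O)c2ccc(OC)c3c2OC(C)(C)C=C3)cc1OCCO`: > 10000 nM, a limit of the assay
Compound 2 `CCC(=O)Oc1cc(/C=C/C(=O)c2ccc(OC)c3c2OC(C)(C)C=C3)ccc1OC`: 90 nM
Compound 3 `COc1ccc(/C=C/C(=O)c2ccc(OC)c3c2OC(C)(C)C=C3)cc1OC(=O)c1ccco1`: 370 nM

In a functional assay on HepG2 cells (Homo sapiens) for cytotoxicity, read by MTT assay (a higher number here means a weaker inhibitor, a lower number a stronger inhibitor), compound 3 gives 370 nM, the higher of the two exact numbers, and its nearest neighbour is described by a 4.1-fold higher number from compound 2 to compound 3 (0.61 log units; beyond the scatter). Compound 4 `COc1ccc(/C=C/C(=O)c2ccc(OC)c3c2OC(C)(C)C=C3)cc1CS(C)(=O)=O` carries (methylsulfonyl)methyl in place of ((furan-2-yl)carbonyl)oxy on an aromatic carbon.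

For the measured compounds named here, no measured step tests this new group. The nearest guides are an at least 110-fold lower number from compound 1 to compound 2 (2.04 log units; beyond the scatter) and an at least 27-fold lower number from compound 1 to compound 3 (1.43 log units; beyond the scatter), both large. Compound 4, like compound 1, lacks the propanoyl and (furan-2-yl)carbonyl groups. A sizeable rise is therefore expected, a 5.4-fold higher number from compound 3 to compound 4 (0.73 log units; beyond the scatter). The estimate for compound 4 is 2000 nM, with an expected range of 350 nM to 10000 nM.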

Compound 4, half-maximal inhibitory concentration: 9180 nM
Compound 4: the middle estimate sits 4.6-fold (0.66 log units) below what was measured; low and high end bracket the measured number.
By their numbers in this assay, from the lowest: compound 2; then compound 3; then compound 4. At a limit, above all of these: compound 1.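

Compound 4 gives an exact number where compound 1 gives only a limit, so the cost of losing each carbonyl-bearing group can now be sized: a 100-fold higher number from compound 2 to compound 4 (2.01 log units; beyond the scatter), and a 25-fold higher number from compound 3 to compound 4 (1.39 log units; beyond the scatter); the third step is an at least 1.0-fold lower number from compound 1 to compound 4 (0.03 log units; that floor lies within the scatter). At this aromatic carbon, ortho to a methoxy group, the two compounds with a carbonyl on the ring oxygen therefore give far lower numbers than compound 4. Compound 1 stands at a limit, so its step to compound 4 cannot be read: the limit of > 10000 nM in this assay, at which 1 of the 4 values shown sits.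

The compounds shown leave open whether the carbonyl alone suffices or its linking oxygen is also needed. An amide at this position, or butanoyloxy with its longer chain, would bear on that.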